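This account rests on a few compounds, and the source may have more. Where it says the series, first, only, none or still open, it means among the compounds named here.

Measured so far in a functional assay on Huh-5-2 cells (Homo sapiens), read by MTT assay; a higher number here means that more compound is tolerated, a lower number that less compound is tolerated:
Compound 1 `O=C(O)c1ccc2c(c1)nc(-c1ccc(OCc3ccccc3-c3ccc(Cl)cc3)cc1)n2C1CCCCC1` gives 25000 nM
Compound 2 `CCCNC(=O)c1ccc(-c2ccc(Cl)cc2)c(COc2ccc(-c3nc4cc(C(=O)O)ccc4n3C3CCCCC3)c(F)c2)c1` gives 24000 nM

These two numbers lie within the usual scatter of repeated measurements, so compound 2 stands level with compound 1. Compound 3 `CC(=O)N(c1ccc(-c2ccc(Cl)cc2)c(COc2ccc(-c3nc4cc(C(=O)O)ccc4n3C3CCCCC3)c(F)c2)c1)C(C)C` has not been measured yet. It keeps the rest of compound 2 but carries acetyl(isopropyl)amino in place of propylcarbamoyl on an aromatic carbon, para to a 4-chlorophenyl group (acetyl(isopropyl)amino in place of propylcarbamoyl on an aromatic carbon). Among the compounds with values here, no measured pair here differs in one place alone, so the data offer no direct guide to this swap. With only the close values of compound 1 25000 nM and compound 2 24000 nM to go on, no change beyond the scatter is expected in this assay. The estimated 1.0-fold higher number from compound 2 to compound 3 (0.02 log units; within the scatter) stays within that scatter. Compound 3 is estimated at 25000 nM, with an expected range from 11000 nM to 50000 nM.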

Compound 3, half-maximal cytotoxic concentration: 20000 nM
Compound 3: middle estimate off by 1.3-fold (0.10 log units), on the high side, and the stated range covers the measured number.
By their numbers in this assay, from the lowest: compounds 3, 2 and 1 (each within the scatter of the next).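

Within the data shown here, this is the first direct reading at this position: on the aromatic carbon para to a 4-chlorophenyl group, acetyl(isopropyl)amino in place of propylcarbamoyl gives (a 1.2-fold lower number from compound 2 to compound 3 (0.08 log units; within the scatter)) in (this assay). The entering group carries 0 hydrogen-bond donors against 1 for the leaving group, and 7 heavy atoms against 6, yet the two compounds still stand level in this read-out. No measurement on these compounds offers an explanation for this result.

As far as these compounds go, whether a primary amine, a sulfonamide or a longer alkyl chain on this carbon would also stay within the scatter remains open. This single pair also says nothing about changes elsewhere on the shared core.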